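This account rests on a few compounds, and the source may have more. Where it says the series, first, only, none or still open, it means among the compounds named here.

- compound 1 `COc1cccc(/C=C/C(=O)C(=Cc2cc(OC)c(OC)c(OC)c2)C(=O)/C=C/c2cccc(OC)c2OC)c1OC`: 230 nM
- compound 2 `COc1cccc(/C=C/C(=O)C(=Cc2ccc(O)c(F)c2)C(=O)/C=C/c2cccc(OC)c2OC)c1OC`: 200 nM

In a functional assay on A549 cells (Homo sapiens) for antiproliferative activity, read by sulforhodamine B assay, with a stated time of 48 h (a lower number here means a stronger inhibitor, a higher number a weaker inhibitor), compound 2 gives 200 nM, within the usual scatter of compound 1 at 230 nM, so the two cannot be told apart. Compound 3 `COc1cc(C=C(C(=O)/C=C/c2cccc(OC)c2OC)C(=O)/C=C/c2cccc(OC)c2OC)cc(OC)c1O` keeps the rest of compound 2 but carries 4-hydroxy-3,5-dimethoxyphenyl in place of 3-fluoro-4-hydroxyphenyl on a double-bonded chain carbon bound to a double-bonded chain carbon. For the measured compounds named here, only one measured step bears on this place: a 1.2-fold lower number from compound 1 to compound 2 (0.06 log units; within the scatter). That swap between 3,4,5-trimethoxyphenyl and 3-fluoro-4-hydroxyphenyl changed the number by no more than the scatter. Going by the values given here, the new group has the hydroxy of the one and methoxy groups like the other, so no step beyond the scatter is expected in this assay. The expected change is a 1.1-fold higher number from compound 2 to compound 3 (0.02 log units; within the scatter). The estimate for compound 3 is 210 nM, with an expected range from 90 nM to 500 nM.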

Compound 3, half-maximal inhibitory concentration: 240 nM
Compound 3: middle estimate off by 1.1-fold (0.06 log units), on the low side; the measured number falls inside the stated range.
By their numbers in this assay, from the lowest: compounds 2, 1 and 3 (each within the scatter of the next).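

In this assay there is a 1.2-fold higher number from compound 2 to compound 3 (0.08 log units; within the scatter), so 4-hydroxy-3,5-dimethoxyphenyl cannot be told apart from 3-fluoro-4-hydroxyphenyl at this place, even though it brings more heavy atoms and more hydrogen-bond acceptors. Putting hydrogen in place of methyl on an oxygen on an aromatic ring gives a 1.0-fold higher number from compound 1 to compound 3 (0.02 log units; within the scatter), so this single change also leaves the number within the scatter, and across these three compounds the ring on this carbon can vary in size and in its fluorine, hydroxy and methoxy groups with no measurable effect. Nothing available explains why these changes make so little difference.

The compounds shown leave open whether this tolerance holds for a ring carrying an amine or a carboxylic acid. They also do not show whether a plain phenyl ring, with no hydroxy or methoxy groups at all, would read the same.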